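The source may hold more compounds than are shown below. What is called first, only, known or untested is meant among the compounds shown, and "the series" means these compounds.

Series notes on variation at the saturated chain carbon bound to an oxygen on a saturated carbon and a saturated ring carbon. Compound 1 `CC(C)(C)C1=C(C(=O)O)N2C(=O)[C@H](CO)[C@H]2O1` gives 5 h in an ADME assay, in phosphate buffer, at 28 degrees C, at pH 7.0; a higher number here means that the compound lasts longer, a lower number that the compound disappears faster. Compound 2 `COC(=O)[C@H](O)[C@H]1C(=O)N2C(C(=O)O)=C(C(C)(C)C)O[C@H]12` gives 6.7 h in this assay, and compound 3 `CC(C)(C)C1=C(C(=O)O)N2C(=O)[C@H]([C@@H](O)c3ccccc3)[C@H]2O1` gives 8.9 h in this assay. The steps of a 1.8-fold higher number from compound 1 to compound 3 (0.25 log units; within the scatter) and a 1.3-fold higher number from compound 2 to compound 3 (0.12 log units; within the scatter) stay within the scatter, as does a 1.3-fold higher number from compound 1 to compound 2 (0.13 log units; within the scatter). Compound 4 `Cn1cc([C@H](O)[C@H]2C(=O)N3C(C(=O)O)=C(C(C)(C)C)O[C@H]23)nn1` carries 1-methyl-1H-1,2,3-triazol-4-yl in place of phenyl on a saturated chain carbon bound to an oxygen on a saturated carbon and a saturated ring carbon. Among the measured compounds shown here, no measured step places a five-membered aromatic ring with hetero atoms at this position; the nearest comparisons, replacing hydrogen or methoxycarbonyl with phenyl, each moved the number by less than the scatter. Expected for compound 4 is therefore a step of a 1.3-fold lower number from compound 3 to compound 4 (0.10 log units; within the scatter) of no more than scatter size, in no clear direction. Compound 4 is estimated at 7 h, range 3.5 h to 14 h, in this assay.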

Compound 4, half-life: 7 h
For compound 4 middle estimate and measured number coincide at the digits printed, and the stated range covers the measured number.
By their numbers in this assay, from the lowest: compounds 1, 2, 4 and 3 (each within the scatter of the next).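

At the saturated chain carbon bound to an oxygen on a saturated carbon and a saturated ring carbon, a five-membered aromatic ring with hetero atoms stays within the scatter in this assay against phenyl (a 1.3-fold lower number from compound 3 to compound 4 (0.10 log units; within the scatter)), methoxycarbonyl (a 1.0-fold higher number from compound 2 to compound 4 (0.02 log units; within the scatter)) and hydrogen (a 1.4-fold higher number from compound 1 to compound 4 (0.15 log units; within the scatter)). The hydrogen-bond acceptors entering with 1-methyl-1H-1,2,3-triazol-4-yl thus leave all four compounds within the scatter of one another. No supporting data bear on the reason for this result. As far as these compounds go, whether an amine or a carboxylic acid at this carbon would step beyond the scatter stays open.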